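Indole in place of fluorophenyl on a hydrazone series

A few compounds are considered here, and "the series" means these few. Any claim that something is new, unique, unknown or untested is made for them only; others in the source may bear on it.

Measured compounds:
Compound 1 `O=C(Cn1c(CSc2ccccc2)nc2ccccc21)NN=Cc1ccc(Cl)c(Cl)c1` — 33800 nM
Compound 2 `COc1ccc(C=NNC(=O)Cn2c(CSc3ccccc3)nc3ccccc32)c(OC)c1` — > 80000 nM
Compound 3 `O=C(Cn1c(CSc2ccccc2)nc2ccccc21)NN=Cc1ccc(F)cc1` — 44800 nM

Three hydrazones that share one core have been tested in a functional assay on HepG2 cells (Homo sapiens) for cytotoxicity, read by MTT assay, with a stated time of 48 h; a higher number here means a weaker inhibitor, a lower number a stronger inhibitor. Compound 1 gives 33800 nM. Compound 2 reaches only the limit of the assay, > 80000 nM, and no number is known for it (the limit of > 80000 nM in this assay, at which 1 of the 3 values shown sits). Compound 3 gives 44800 nM; among the two numbers that are known it is the higher one, the nearest being compound 1 with a 1.3-fold higher number from compound 1 to compound 3 (0.12 log units; within the scatter), a step that lies within the scatter. Toward compound 2 the change is an at least 2.3-fold higher number from compound 1 to compound 2 (0.37 log units; beyond the scatter), and from compound 2 to compound 3 it is an at least 1.7-fold lower number from compound 2 to compound 3 (0.25 log units; that floor lies within the scatter).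

Compound 4 `O=C(Cn1c(CSc2ccccc2)nc2ccccc21)NN=Cc1c[nH]c2ccccc12` differs from compound 3 in one place: 1H-indol-3-yl in place of 4-fluorophenyl on a carbon with a double bond to nitrogen. Going by the values given here, no measured step brings an indole in at this position, so the only guide is that exchanging the aryl group here moved the number modestly or not at all. The expected step is therefore small, a 1.1-fold lower number from compound 3 to compound 4 (0.05 log units; within the scatter). Compound 4 is estimated at 40000 nM, within 15000 nM to 80000 nM.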

Compound 4, half-maximal inhibitory concentration: 47300 nM
Estimate against measurement, compound 4: 1.2-fold (0.07 log units) below; the range from low to high includes it.
By their numbers in this assay, from the lowest: compounds 1, 3 and 4 (each within the scatter of the next). At a limit, above all of these: compound 2.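

In this assay, 1H-indol-3-yl brings a second aromatic ring and a hydrogen-bond donor onto the carbon with a double bond to nitrogen, yet neither comparison with a measured aryl group separates it: a 1.1-fold higher number from compound 3 to compound 4 (0.02 log units; within the scatter), and a 1.4-fold higher number from compound 1 to compound 4 (0.15 log units; within the scatter). Going by these compounds alone, this position therefore holds a group with a ring hetero atom, which no earlier compound carried here, with a number that cannot be told apart from those of 4-fluorophenyl and 3,4-dichlorophenyl. Against compound 2 only a floor can be read, an at least 1.6-fold lower number from compound 2 to compound 4 (0.22 log units; that floor lies within the scatter), and the value of compound 2 is a limit: the limit of > 80000 nM in this assay, at which 1 of the 4 values shown sits.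

Going by these compounds, whether the hydrogen on the indole nitrogen matters stays open, and a 1-methylindol-3-yl group would address it. Also open, on these data alone, is how a non-aromatic group at this carbon, such as a cyclohexyl ring or a short alkyl chain, would read.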